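Swapping chloro for fluoro on the aniline ring of a purine

The source may report more compounds than this note shows. Statements on the series, on what has been measured and on what is new or still open speak of the compounds shown alone.

Measured so far:
compound 1 `COc1cccc(Nc2nc(Cl)nc3[nH]cnc23)c1`, 1900 nM
compound 2 `Clc1cccc(Nc2nc(Cl)nc3[nH]cnc23)c1`, 3900 nM

Both compounds were tested in an assay for inhibition of cytokinin dehydrogenase 2 (Arabidopsis thaliana); on this read-out lower numbers stand for stronger inhibition and higher numbers for weaker inhibition. Going by the values given here, compound 2 gives the highest of the two numbers, that is the weaker inhibition; the only neighbour is compound 1, and the step of a 2.1-fold higher number from compound 1 to compound 2 (0.31 log units; beyond the scatter) is modest but beyond the scatter.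

Compound 3 `Fc1cccc(Nc2nc(Cl)nc3[nH]cnc23)c1` differs from compound 2 by fluoro in place of chloro on an aromatic carbon, placed on an aromatic carbon of the six-membered carbon ring, meta to a large group. Among the compounds with values here, no measured step exchanges one halogen for another; the single step known, a 2.1-fold higher number from compound 1 to compound 2 (0.31 log units; beyond the scatter), concerns a different replacement and so gives only indirect guidance. The expected step of a 1.2-fold lower number from compound 2 to compound 3 (0.09 log units; within the scatter) is therefore small, within the scatter in either direction. For compound 3 the estimate in this assay is 3200 nM, with a range from 1300 nM to 8000 nM.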

Compound 3, half-maximal inhibitory concentration: 7500 nM
The estimate for compound 3 lay 2.3-fold (0.37 log units) below the measured number, within the range that was stated.
By their numbers in this assay, from the lowest: compound 1; then compounds 2 and 3 (each within the scatter of the next).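

Exchanging one halogen for the other at this place on the aromatic ring gives a 1.9-fold higher number from compound 2 to compound 3 (0.28 log units; within the scatter) in this assay, so this assay does not separate chloro from fluoro here. Methoxy now stands apart from two halogens rather than one: fluoro in its place gives a 3.9-fold higher number from compound 1 to compound 3 (0.60 log units; beyond the scatter), which leaves compound 1 as the strongest inhibitor of the three. Nothing available here explains why methoxy and the two halogens differ in this way.

Still open, as far as these compounds go, is how a hydroxyl, an amine or a simple methyl at this place would compare with methoxy. Also open, from the compounds shown here alone, is whether methoxy would keep its lead over chloro and fluoro if all three groups were moved to another carbon of the same ring.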